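Benzyl to phenyl on the pyrrole nitrogen of compound 1

A few compounds are considered here, and "the series" means these few. Any claim that something is new, unique, unknown or untested is made for them only; others in the source may bear on it.

Three compounds have numbers in an assay on isolated protein for inhibition of alpha-mannosidase (Canavalia ensiformis), read by spectrophotometry, with a stated time of 10 min; a lower number here means a stronger inhibitor, a higher number a weaker inhibitor. Compound 1 `Cc1cc2c(c(=O)[nH]1)C(=O)O/C2=C\c1ccc(CO)n1Cc1ccccc1` gives 92300 nM there, the highest of the three. Compound 2 `OCc1ccc2n1C[C@@H](c1ccc(O)cc1)OC2` gives 14000 nM, and compound 3 `OC[C@@H]1N[C@@H](c2ccc(O)cc2)[C@H](O)[C@H]1O` gives 28000 nM; both numbers sit beyond the scatter below compound 1, so compound 1 is the weakest inhibitor measured so far.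

Compound 4 `Cc1cc2c(c(=O)[nH]1)C(=O)O/C2=C\c1ccc(CO)n1-c1ccccc1` has no number yet. It differs from compound 1 in one place: phenyl in place of benzyl on an aromatic nitrogen. Within the data shown here, no measured pair shows the effect of this change, so the size of its step is unknown; the expectation is a step within the scatter, with no clear direction, as a benzyl and a phenyl differ by a single carbon here.

Compound 4 is therefore expected at about 90000 nM, between 30000 nM and 300000 nM, meaning an expected step of a 1.0-fold lower number from compound 1 to compound 4 (0.01 log units; within the scatter) in this assay.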

Compound 4, half-maximal inhibitory concentration: 61400 nM
Compound 4: the middle estimate sits 1.5-fold (0.17 log units) above what was measured; the measured number falls inside the stated range.
By their numbers in this assay, from the lowest: compounds 2 and 3 (each within the scatter of the next); then compounds 4 and 1 (each within the scatter of the next).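

In this assay phenyl in place of benzyl on the aromatic nitrogen gives a 1.5-fold lower number from compound 1 to compound 4 (0.18 log units; within the scatter) and so stays within the scatter. Among these compounds, this is the first pair at this position, and on the core of compound 1 the two groups cannot be told apart by this read-out. No evidence bears on this result.

From the compounds shown here alone, whether a longer chain such as phenethyl on this nitrogen would separate from compound 1 remains open. So does the effect of an amine or a carboxylic acid on the phenyl ring.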